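Formyl Added to the Core of a Chloro Compound

The source may report more compounds than this note shows. Statements on the series, on what has been measured and on what is new or still open speak of the compounds shown alone.

Compound 1 `Cc1ccc2c(Cc3nn4cc(-c5ccc(Cl)cc5)nc4s3)coc2c1` gives the higher of the two measured numbers in a functional assay on the whole organism (strain Wistar albino) for inhibition, with Rattus norvegicus as the target, read by paw edema, with a stated time of 2 h, at a dose of 100 mg/kg by the oral route; on this read-out higher numbers stand for more inhibition at the one dose given (going by the name of the read-out) and lower numbers for less inhibition: compound 1 gives 42.1%. Going by the values given here, compound 2 `Cc1ccc2c(Cc3nn4cc(-c5ccc([N+](=O)[O-])cc5)nc4s3)coc2c1` gives 24.3% in this assay, and the one measured step, a number 17.8 percentage points lower from compound 1 to compound 2 (beyond the scatter), comes from swapping nitro for chloro on an aromatic carbon. Compound 3 `Cc1ccc2c(Cc3nn4c(C=O)c(-c5ccc(Cl)cc5)nc4s3)coc2c1` differs from compound 1 at a different site: formyl in place of hydrogen on an aromatic carbon. Among the compounds with values here, the single measured step does not touch the part of the molecule altered here, so it bears on the change only as a sign that one group swap on this scaffold can move the read-out by a modest amount. With no closer guide, compound 3 is expected to show a step of a number 4.1 percentage points lower from compound 1 to compound 3 (within the scatter), within the scatter. Compound 3 is therefore estimated at 38%, with a range from 22% to 55%.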

Compound 3, a percentage reported as inhibition, in the whole organism at one dose (the size of the read-out at that dose, not a potency): 24.3%
Estimate against measurement, compound 3: 13.7 percentage points above, within the range that was stated.
By their numbers in this assay, from the lowest: compounds 2 and 3 (each within the scatter of the next); then compound 1.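

The carbon on the five-membered aromatic ring with 2 nitrogen, which carries only hydrogen in compound 1, proves sensitive in this assay: placing formyl there gives a number 17.8 percentage points lower from compound 1 to compound 3 (beyond the scatter). Going by these compounds alone, the earlier step concerned only the chloro group on the aromatic ring, so this is the first sign that a second site on the shared core also affects the read-out, here with a group of just 2 heavy atoms. Nothing available explains why the number falls at this position.

As far as these compounds go, it remains open whether the fall belongs to formyl in particular or would follow any group on this carbon, a question that a methyl, an amine or a carboxylic acid at the same place would address. Also open, from the compounds shown here alone, is whether the same change would give a similar step on the nitro compound 2.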